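Amide substituent variation on a shared core, antiproliferative read-out

The compounds below may be only part of what the source reports. "The series", "measured", "known", "first", "only" and "open" are said of these compounds alone.

Measured compounds:
- compound 1 `CCn1c(C(=O)N[C@@H](CC(=O)OC)C(=O)OC)ccc1C(CC)(CC)c1ccc(OCS(=O)(=O)c2ccccc2)c(C)c1`: in a functional assay on BXPC-3 cells (Homo sapiens) for antiproliferative activity, read by MTT assay, with a stated time of 24 h (a higher number here means a weaker inhibitor, a lower number a stronger inhibitor), compound 1 gives > 50000 nM, which is a limit of the assay and not a number.
- compound 2 `CCn1c(C(=O)NCCO)ccc1C(CC)(CC)c1ccc(OCS(=O)(=O)c2ccccc2)c(C)c1`: in this assay compound 2 gives 19900 nM.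
- compound 3 `CCn1c(C(=O)NC2(CO)CC2)ccc1C(CC)(CC)c1ccc(OCS(=O)(=O)c2ccccc2)c(C)c1`: in this assay compound 3 gives 45400 nM.

Compound 1 stands at the ceiling of the assay; only a limit is known for it (the limit of > 50000 nM in this assay, at which 1 of the 3 values shown sits). Both steps away from it are therefore floors: an at least 2.5-fold lower number from compound 1 to compound 2 (0.40 log units; beyond the scatter), and an at least 1.1-fold lower number from compound 1 to compound 3 (0.04 log units; that floor lies within the scatter). Between the two measured amides, a 2.3-fold higher number from compound 2 to compound 3 (0.36 log units; beyond the scatter).

Compound 4 `CCn1c(C(=O)N[C@@H](C(=O)O)C(C)C)ccc1C(CC)(CC)c1ccc(OCS(=O)(=O)c2ccccc2)c(C)c1` differs from compound 1 at the same amide-type nitrogen: 1-carboxy-2-methylpropyl in place of 1,2-bis(methoxycarbonyl)ethyl on an amide-type nitrogen. Both measured steps from compound 1 bear on this change, since each swaps out the same group at the same place; one is at least modest, the other has no determined size. Among the compounds with values here, no measured step covers the 1-carboxy-2-methylpropyl group itself, so the expectation rests on compound 1 being at the limit and on the step sizes seen. For compound 4 the expected step is an at least 1.2-fold lower number from compound 1 to compound 4 (0.09 log units; that floor lies within the scatter). Compound 4 is expected at 40000 nM. The expected range for compound 4 runs from 15000 nM to 100000 nM, with a real chance that only a limit is reported again.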

Compound 4, half-maximal inhibitory concentration: 13900 nM
For compound 4 the middle estimate is 2.9-fold (0.46 log units) above the measured one, and the stated range ends above it.
By their numbers in this assay, from the lowest: compounds 4 and 2 (each within the scatter of the next); then compound 3. At a limit, above all of these: compound 1.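

With 1-carboxy-2-methylpropyl in place of 1,2-bis(methoxycarbonyl)ethyl on the amide-type nitrogen, this assay shows an at least 3.5-fold lower number from compound 1 to compound 4 (0.55 log units; beyond the scatter); this step is only a floor, as compound 1 remains at a limit of the assay and not a number. A substituent bearing a carboxylic acid therefore gives a measured value at this position, where the earlier measured values came only from hydroxyl-bearing substituents. It cannot be separated from 2-hydroxyethyl, with a 1.4-fold lower number from compound 2 to compound 4 (0.16 log units; within the scatter), but it does separate from 1-(hydroxymethyl)cyclopropyl, with a 3.3-fold lower number from compound 3 to compound 4 (0.51 log units; beyond the scatter).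

The compounds shown do not tell whether the carboxylic acid or the branched chain of 1-carboxy-2-methylpropyl accounts for the step from compound 3. The methyl ester of this group, or a primary amine on the same chain, would bear on that question.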